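This account rests on a few compounds, and the source may have more. Where it says the series, first, only, none or still open, it means among the compounds named here.

Three compounds of the series have numbers in an assay on isolated protein for inhibition of MAP kinase-activated protein kinase 2 (Homo sapiens), read by HTRF, tested at 10 uM; on this read-out higher numbers stand for more inhibition at the one concentration tested (going by the name of the read-out) and lower numbers for less inhibition. Compound 1 `O=C(C1CCN(c2nccc(Nc3ccccc3)n2)CC1)N1CC[C@@H](O)C1` gives 4%. Compound 2 `Clc1ccc2sc(CN3CCN(c4ncnc5c4CN(Cc4ccccc4)CC5)CC3)cc2c1` gives 1%; on the numbers shown it stands second highest of the three, with compound 3 nearest and compound 1 furthest, both gaps within the scatter. Compound 3 `O=C(CN1CCN(c2ncnc3c2CN(Cc2ccccc2)CC3)CC1)Nc1cc(F)ccc1F` gives 0%. Within the data shown here, the only step between compounds that differ in one place, a number 1 percentage points lower from compound 2 to compound 3 (within the scatter), lies within the scatter; all three numbers sit near the floor of this assay.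

Compound 4 `Cc1cc(C(=O)N2CCN(c3ncnc4c3CN(Cc3ccccc3)CC4)CC2)c(C)n1C` is not yet measured. It differs from compound 2 by (1,2,5-trimethyl-1H-pyrrol-3-yl)carbonyl in place of (5-chloro-1-benzothiophen-2-yl)methyl on an amine nitrogen in a ring. The step from compound 2 to compound 3 bears on it, as it also exchanges a group on the same ring nitrogen of the shared core of compound 2, and that step stayed within the scatter. No movement beyond the scatter is therefore expected in this assay, in either direction. Compound 4 is estimated at 2%, within -6% to 10%, which means an expected step of a number 1 percentage points higher from compound 2 to compound 4 (within the scatter).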

Compound 4, a percentage reported as inhibition, at one concentration (the size of the read-out at that concentration, not a potency): 0%
Estimate against measurement, compound 4: 2 percentage points above; measured number inside the range.
By their numbers in this assay, from the lowest: compounds 3, 4, 2 and 1 (each within the scatter of the next).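

In this assay the exchange on the amine nitrogen in a ring gives a number 1 percentage points lower from compound 2 to compound 4 (within the scatter). The earlier step changed a group on a saturated chain carbon and kept that carbon on the ring nitrogen, whereas this one puts a carbonyl on the nitrogen itself and replaces the two aromatic rings of (5-chloro-1-benzothiophen-2-yl)methyl with the single five-membered aromatic ring of (1,2,5-trimethyl-1H-pyrrol-3-yl)carbonyl, so this position now shows no response to either kind of exchange. Nothing available explains this absence of response.

As far as these compounds go, with every number in this small set near the floor of the assay, it remains open whether any group on this nitrogen can raise inhibition. A carboxylic acid or a primary amine at the end of a longer chain in this place would test that.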